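Ethynyl on the chain of compound 2

The compounds below may be only part of what the source reports. "The series", "measured", "known", "first", "only" and "open" are said of these compounds alone.

Measured in a functional assay on T98G cells (Homo sapiens) for inhibition, read by colorimetric assay and MTT assay, with a stated time of 72 h; on this read-out higher numbers stand for weaker inhibition and lower numbers for stronger inhibition:
- compound 1 `Cn1c2cnc1OCCCCCCCCOc1cc(F)ccc1-2`: 69000 nM
- compound 2 `CCCCOc1ncc(-c2ccccc2OC)n1C`: 96000 nM

Compound 2 (96000 nM) stands within the scatter of compound 1 (69000 nM), so these two numbers give no ranking. For the measured compounds named here, the two structures differ in more than one place, and no measured pair differs in one place only. The effect of a single change on the chain has therefore not been observed in this series.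

The change ethynyl in place of hydrogen on a saturated chain carbon, four bonds along the chain from an oxygen on an aromatic ring leads from compound 2 to compound 3 `C#CCCCCOc1ncc(-c2ccccc2OC)n1C` and adds an ethynyl group on a saturated chain carbon, four bonds along the chain from an oxygen on an aromatic ring. No step beyond the scatter is expected in this assay, and no direction is favoured. Going by the values given here, this expectation rests on very little: only two values are available, and neither isolates the change. The expected 1.4-fold lower number from compound 2 to compound 3 (0.14 log units; within the scatter) is correspondingly small and uncertain. The estimate for compound 3 is 70000 nM, with the measurement expected to fall from 30000 nM to 150000 nM in most repeats.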

Compound 3, half-maximal inhibitory concentration: 35000 nM
For compound 3 the middle estimate is 2.0-fold (0.30 log units) above the measured one; low and high end bracket the measured number.
By their numbers in this assay, from the lowest: compounds 3, 1 and 2 (each within the scatter of the next, the first and the last beyond it).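

For the compounds shown here, the pair of compound 2 and compound 3 is the first to differ in one place only, so a single change on the chain can now be read in this assay as a 2.7-fold lower number from compound 2 to compound 3 (0.44 log units; beyond the scatter) and this modest step lies beyond the scatter. At this position, on a saturated chain carbon, four bonds along the chain from an oxygen on an aromatic ring, ethynyl in place of hydrogen therefore brings a lower number and no loss in this read-out, although this rests on a single pair. Nothing measured here bears on what lies behind the step.

The compounds shown leave open whether the step belongs to the triple bond itself or simply to the 2 added carbon atoms, a question that a fully saturated longer chain would address. They also leave open how this chain carbon responds to groups of another kind, such as an amine or a carboxylic acid, and whether the same change would give a step of similar size on another core.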